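The compounds below may be only part of what the source reports. "The series", "measured", "known", "first", "only" and "open" are said of these compounds alone.

Measured so far in a physicochemical assay for lipophilicity, measured as octanol-water partition; a lower number here means a more polar compound, a higher number a more lipophilic compound:
compound 1 `CCO/N=C/Nc1cc(Cl)c(CC)c(Cl)c1` gives 4.8
compound 2 `CCO/N=C/Nc1cc(Cl)c([S+]([O-])CC)c(Cl)c1` gives 2.9
compound 3 `CCO/N=C/Nc1cc(Cl)c(O)c(Cl)c1` gives 2.8

Compound 1 stands highest of the three numbers in this assay. The nearest of the others is compound 2, a number 1.90 log units lower from compound 1 to compound 2 (beyond the scatter); the furthest is compound 3, a number 2.00 log units lower from compound 1 to compound 3 (beyond the scatter). Compounds 2 and 3 lie within the scatter of each other, a number 0.10 log units lower from compound 2 to compound 3 (within the scatter).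

The step under consideration runs from compound 1 to compound 4 `CCO/N=C/Nc1cc(Cl)c(OCCCl)c(Cl)c1`. The change:
2-chloroethoxy in place of ethyl on an aromatic carbon

Both measured steps out of compound 1 replace the same ethyl on the same aromatic carbon and so bear on this one; both were large drops, a number 1.90 log units lower from compound 1 to compound 2 (beyond the scatter) and a number 2.00 log units lower from compound 1 to compound 3 (beyond the scatter). Neither, however, brings in a 2-chloroethoxy group: one puts a hydroxy there, the other a group of 2 carbon, 1 oxygen, 1 sulfur. The entering group here carries one hydrogen-bond acceptor and no donor, and keeps two carbons plus a chlorine. A downward step in this assay is expected, but clearly smaller than either measured drop, and it may fall inside the scatter.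

For compound 4 the expected value in this assay is 4.4, with a range from 3.9 to 4.9. This estimate means a number 0.40 log units lower from compound 1 to compound 4 (beyond the scatter).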

Compound 4, partition coefficient: 4
Estimate against measurement, compound 4: 0.40 log units above; measured number inside the range.
By their numbers in this assay, from the lowest: compounds 3 and 2 (each within the scatter of the next); then compound 4; then compound 1.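

For the compounds shown here, at this aromatic carbon, ortho to two chloro groups, replacing ethyl need not cost as much as the earlier compounds suggested: in this assay, 2-chloroethoxy in place of ethyl gives a number 0.80 log units lower from compound 1 to compound 4 (beyond the scatter), a modest step beside the large drops seen so far. The oxygen on the aromatic carbon does not by itself fix the number, as 2-chloroethyl in place of hydrogen on that oxygen gives a number 1.20 log units higher from compound 3 to compound 4 (beyond the scatter) and recovers a large part of the ground between the hydroxy compound and the ethyl compound. Heavy-atom count does not fix it either, since the two groups of 4 heavy atoms, which differ in holding chlorine or sulfur, are separated by a number 1.10 log units higher from compound 2 to compound 4 (beyond the scatter) in this series.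

Going by these compounds, how much of the step from ethyl belongs to the chlorine of the new chain remains open, as does where an ethoxy group, a longer chain or an amine at this carbon would stand against compound 4. The compounds shown come with no measurement that explains any of these differences.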